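Fluoro to methoxy on the aryl ring of compound 1

The source may report more compounds than this note shows. Statements on the series, on what has been measured and on what is new or still open speak of the compounds shown alone.

Among the compounds with values here, compound 1, `O=C(/C=C\Nc1ccc(Cl)cc1)c1cn(-c2ccccc2)nc1-c1ccc(F)cc1`, is one of two compounds measured in a functional assay on PC-3 cells (Homo sapiens) for antiproliferative activity, read by MTT assay, with a stated time of 48 h (a lower number here means a stronger inhibitor, a higher number a weaker inhibitor), where compound 1 gives 3800 nM. Within the data shown here, its only neighbour is compound 2, `O=C(/C=C\Nc1ccc(O)cc1)c1cn(-c2ccccc2)nc1-c1ccc(F)cc1`, which in this assay gives 2600 nM; the step of a 1.5-fold lower number from compound 1 to compound 2 (0.16 log units; within the scatter) leaves the two within the scatter, so compound 1 holds the highest of the two numbers without being separated from compound 2.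

Compound 3, `COc1ccc(-c2nn(-c3ccccc3)cc2C(=O)/C=C\Nc2ccc(Cl)cc2)cc1`, is not yet measured. It differs from compound 1 by methoxy in place of fluoro on an aromatic carbon. Among the measured compounds shown here, the one measured step, from compound 1 to compound 2, changes a different ring and a different group, so it does not bear on this change; it was itself within the scatter. For the measured compounds named here, with no relevant step to lean on, compound 3 is expected to show no step beyond the scatter, a 1.1-fold lower number from compound 1 to compound 3 (0.04 log units; within the scatter). For compound 3 the estimate is therefore 3500 nM, with a range from 1500 nM to 8000 nM.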

Compound 3, half-maximal inhibitory concentration: 3890 nM
Compound 3: middle estimate off by 1.1-fold (0.05 log units), on the low side; low and high end bracket the measured number.
By their numbers in this assay, from the lowest: compounds 2, 1 and 3 (each within the scatter of the next).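

In this assay the exchange of 4-fluorophenyl for 4-methoxyphenyl gives a 1.0-fold higher number from compound 1 to compound 3 (0.01 log units; within the scatter), so compound 3 is not separated from compound 1. Within the data shown here, the earlier step concerned only the chloro-bearing aromatic ring, so this is the first reading at the position para to a large group, and there a methoxy, with 2 heavy atoms and a hydrogen-bond acceptor, stands in for a single fluorine with no step beyond the scatter. Nothing measured on these compounds speaks to why the number stays put.

As far as these compounds go, whether an amine, a carboxylic acid or a longer alkoxy chain at this position would move the number remains open. With every step so far within the scatter, the compounds shown do not yet reveal any change that separates one compound from another.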